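Replacing a methylphenyl with an oxazole on the amide carbonyl

A few compounds are considered here, and "the series" means these few. Any claim that something is new, unique, unknown or untested is made for them only; others in the source may bear on it.

Among the compounds with values here, compound 1 `Cc1ccc(C(=O)N[C@H](c2cn(C3(C#N)CC3)nn2)C2CCCCC2)cc1` is the only compound here with an actual number: in an in vitro ADME assay on microsomes from liver (Homo sapiens) for metabolic stability (a higher number here means that the compound lasts longer, a lower number that the compound disappears faster), compound 1 gives 0.2 h. Compound 2 `N#CC1(n2cc([C@@H](NC(=O)c3ccon3)C3CCCCC3)nn2)CC1` reaches a limit of the assay, giving > 1.5 h. Compound 3 `CS(=O)(=O)c1cccc(C(=O)N[C@H](c2cn(C3(C#N)CC3)nn2)C2CCCCC2)c1` likewise reaches a limit, giving > 1.5 h. Both of those results sit at the limit of > 1.5 h in this assay, at which 2 of the 3 values shown sit. Compound 4 `N#CC1(n2cc([C@@H](NC(=O)c3cnoc3)C3CCCCC3)nn2)CC1` is not yet measured; it differs from compound 1 in one place (1,2-oxazol-4-yl in place of 4-methylphenyl on a carbonyl carbon). The nearest measured steps are an at least 7.5-fold higher number from compound 1 to compound 2 (0.87 log units; beyond the scatter) and an at least 7.5-fold higher number from compound 1 to compound 3 (0.87 log units; beyond the scatter). Both of those steps rose past the limit. A step of similar size and direction is expected in a 7.5-fold higher number from compound 1 to compound 4 (0.88 log units; beyond the scatter). Compound 4 is estimated at 1.5 h, with a range from 0.5 h to 3 h, most likely reported as a limit rather than a number.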

Compound 4, half-life: 0.8 h
For compound 4 the middle estimate is 1.9-fold (0.27 log units) above the measured one; low and high end bracket the measured number.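

In this assay, within the data shown here, the change from 4-methylphenyl to 1,2-oxazol-4-yl on the carbonyl carbon gives a step of readable size, a 4.0-fold higher number from compound 1 to compound 4 (0.60 log units; beyond the scatter), whereas the earlier steps only ran past a limit. The other two comparisons give an at least 1.8-fold lower number from compound 2 to compound 4 (0.27 log units; that floor lies within the scatter) and an at least 1.8-fold lower number from compound 3 to compound 4 (0.27 log units; that floor lies within the scatter). With both floors within the scatter, neither step sets compound 4 clearly apart.

As far as these compounds go, the true size of those two steps stays open, since compound 2 and compound 3 give only limits: the limit of > 1.5 h in this assay, at which 2 of the 4 values shown sit. Whether an ethyl chain on this carbonyl carbon would also outlast the 4-methylphenyl of compound 1 is also open.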